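Methoxy to bromo on the arylidene phenyl ring

The source may report more compounds than this note shows. Statements on the series, on what has been measured and on what is new or still open speak of the compounds shown alone.

Measured compounds:
- Compound 1, `O=C1N=C(N2CCC[C@H]2C(=O)Nc2ccc3ncnc(Nc4cccc(Cl)c4)c3c2)S/C1=C/c1ccc(Br)s1`: in a functional assay on HepG2 cells (Homo sapiens) for antiproliferative activity, read by MTT assay (on this read-out lower numbers stand for stronger inhibition and higher numbers for weaker inhibition), compound 1 gives > 50000 nM, which is a limit of the assay and not a number (the limit of > 50000 nM in this assay, at which 1 of the 3 values shown sits).
- Compound 2, `O=C1N=C(N2CCC[C@H]2C(=O)Nc2ccc3ncnc(Nc4cccc(Cl)c4)c3c2)S/C1=C/c1cccc(Br)n1`: in this assay compound 2 gives 2700 nM.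
- Compound 3, `COc1ccccc1/C=C1/SC(N2CCC[C@H]2C(=O)Nc2ccc3ncnc(Nc4cccc(Cl)c4)c3c2)=NC1=O`: in this assay compound 3 gives 22100 nM.

Among the two numbers shown, compound 3 stands highest; its nearest neighbour is compound 2, separated by an 8.2-fold higher number from compound 2 to compound 3 (0.91 log units; beyond the scatter). Compound 4, `O=C1N=C(N2CCC[C@H]2C(=O)Nc2ccc3ncnc(Nc4cccc(Cl)c4)c3c2)S/C1=C/c1ccccc1Br`, has not yet been measured. It differs from compound 3 by bromo in place of methoxy on an aromatic carbon. Going by the values given here, no measured step exchanges one substituent on the phenyl ring for another: an at least 18-fold lower number from compound 1 to compound 2 (1.26 log units; beyond the scatter) swaps one heteroaryl for another, and an at least 2.2-fold lower number from compound 1 to compound 3 (0.35 log units; beyond the scatter) swaps a heteroaryl for 2-methoxyphenyl. Among the compounds with values here, the measured steps show only that the group on the double-bonded chain carbon can move the number widely, so the step to compound 4 is guessed with little support. Compound 4 is expected to give 12000 nM in this assay, between 3000 nM and 45000 nM. The expected step is a 1.8-fold lower number from compound 3 to compound 4 (0.27 log units; within the scatter).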

Compound 4, half-maximal inhibitory concentration: 24300 nM
The estimate for compound 4 lay 2.0-fold (0.31 log units) below the measured number; the range from low to high includes it.
By their numbers in this assay, from the lowest: compound 2; then compounds 3 and 4 (each within the scatter of the next). At a limit, above all of these: compound 1.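

In this assay, going by these compounds alone, the first exchange on the phenyl ring itself gives a 1.1-fold higher number from compound 3 to compound 4 (0.04 log units; within the scatter) and so does not separate bromo from methoxy on this aromatic carbon, ortho to a large group. Bromo alone does not go with the lower number, as 2-bromophenyl in place of 6-bromopyridin-2-yl gives a 9.0-fold higher number from compound 2 to compound 4 (0.95 log units; beyond the scatter) even though both groups carry bromo. Against 5-bromothiophen-2-yl, 2-bromophenyl gives an at least 2.0-fold lower number from compound 1 to compound 4 (0.31 log units; beyond the scatter) and this step has only one bound, as compound 1 stands at a limit of the assay: the limit of > 50000 nM in this assay, at which 1 of the 4 values shown sits.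

The compounds shown leave open whether the same flat result would hold for an amine or a carboxylic acid at this place on the phenyl ring. They also leave open whether a pyridin-2-yl without bromo would keep the number of compound 2.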